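The source may report more compounds than this note shows. Statements on the series, on what has been measured and on what is new or still open speak of the compounds shown alone.

Working notes on the series, read in a functional assay on MCF7 cells (Homo sapiens) for antiproliferative activity, with a stated time of 5 days; a lower number here means a stronger inhibitor, a higher number a weaker inhibitor. For the measured compounds named here, compound 2 (`CCCCc1ccc2[nH]c(-c3ccc(OC)cc3)c(/C=N/NC(=O)c3ccc(F)cc3)c2c1`) gives 84 nM, the lowest of the three numbers so far, and its gaps to the other two lie beyond the scatter. Compound 3 (`CCCCc1ccc2[nH]c(-c3ccc(C(F)(F)F)cc3)c(/C=N/NC(=O)c3ccc(OC)cc3)c2c1`) gives 618 nM, and compound 1 (`CCCCc1ccc2[nH]c(-c3ccc(C(F)(F)F)cc3)c(/C=N/NC(=O)c3ccc(Cl)cc3)c2c1`) gives 1060 nM. The next step leads to compound 4 (`CCCCc1ccc2[nH]c(-c3ccc(OC)cc3)c(/C=N/NC(=O)c3ccc([N+](=O)[O-])cc3)c2c1`), with nitro in place of fluoro on an aromatic carbon, para to a large group: nitro in place of fluoro on an aromatic carbon. Going by the values given here, one measured step bears on this change: a 1.7-fold lower number from compound 1 to compound 3 (0.23 log units; within the scatter), with methoxy in place of chloro on an aromatic carbon. Among the compounds with values here, that step stays within the scatter, but its two compounds carry trifluoromethyl where compound 2 and compound 4 carry methoxy, and no nitro compound has been measured. The support is therefore thin. A small change is expected, with no firm direction and only a slight lean towards a higher number. The expected step is a 1.4-fold higher number from compound 2 to compound 4 (0.15 log units; within the scatter). For compound 4 the estimated value is 120 nM, with an expected range of 40 nM to 350 nM.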

Compound 4, half-maximal inhibitory concentration: 312 nM
Beside the measured number, compound 4's estimate is 2.6-fold (0.41 log units) below it; low and high end bracket the measured number.
By their numbers in this assay, from the lowest: compound 2; then compounds 4, 3 and 1 (each within the scatter of the next, the first and the last beyond it).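

Nitro in place of fluoro on an aromatic carbon, para to a large group, gives a 3.7-fold higher number from compound 2 to compound 4 (0.57 log units; beyond the scatter) in this assay and so shows that the group at this place can shift the number beyond the scatter. The earlier step, a 1.7-fold lower number from compound 1 to compound 3 (0.23 log units; within the scatter) on compounds carrying trifluoromethyl rather than methoxy, did not show this. No measurement at hand speaks to the cause of the new step.

Going by these compounds, with only fluoro and nitro compared on the methoxy compounds, it remains open whether the same change gives a similar step on the trifluoromethyl compounds. Also open, on these data alone, is how an amine, a carboxylic acid or a nitrile at this place would read against fluoro, and so whether nitro marks a general trend or a single case.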